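The compounds below may be only part of what the source reports. "The series", "measured", "known", "first", "only" and "open" are said of these compounds alone.

Series notes, cytotoxicity. Three compounds are in hand. Compound 1 `COc1cccc(CNCCCNc2ccnc3cc(C4CCCCC4)ccc23)c1O` gives 1080 nM in an ADME assay on HepG2 cells (Homo sapiens) for cytotoxicity, read by luminescence, CellTiter-Glo and ATP content, with a stated time of 72 h; on this read-out lower numbers stand for an effect already at smaller amounts and higher numbers for an effect only at larger amounts of compound. Compound 2 `Fc1ccc(-c2ccc3c(NCCCNCc4ccco4)ccnc3c2)cc1` gives 7760 nM in this assay, and compound 3 `COc1cccc(CNCCCNc2ccnc3cc(-c4ccc(F)cc4)ccc23)c1O` gives 6840 nM. Compound 2 stands at the highest of the three numbers; its number and that of compound 3 sit within the scatter of each other, while compound 1 lies well apart with the lowest number.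

Of the two measured steps, the exchange on the saturated chain carbon, a 1.1-fold lower number from compound 2 to compound 3 (0.05 log units; within the scatter), lies within the scatter. Among the compounds with values here, the exchange on the aromatic carbon, a 6.3-fold higher number from compound 1 to compound 3 (0.80 log units; beyond the scatter), is the only step at the pendant group and is the one that bears on the present change, though it is not the same exchange.

Compound 4 `CC(C)(C)c1ccc(-c2ccc3c(NCCCNCc4ccco4)ccnc3c2)cc1` differs from compound 2 in one place: tert-butyl in place of fluoro on an aromatic carbon. The move from cyclohexyl to 4-fluorophenyl raised the number; the present move in the same position goes the other way in bulk, so a step toward a lower number is expected, of moderate size, a 2.2-fold lower number from compound 2 to compound 4 (0.35 log units; beyond the scatter). The estimate for compound 4 in this assay is 3500 nM, in a range from 1200 nM to 12000 nM.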

Compound 4, half-maximal effective concentration: 3150 nM
For compound 4 the middle estimate is 1.1-fold (0.05 log units) above the measured one; the measured number falls inside the stated range.
By their numbers in this assay, from the lowest: compound 1; then compound 4; then compounds 3 and 2 (each within the scatter of the next).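

In this assay, within the data shown here, the change from 4-fluorophenyl to 4-(tert-butyl)phenyl gives a 2.5-fold lower number from compound 2 to compound 4 (0.39 log units; beyond the scatter), the first step in which the pendant ring stays and only its group para to a large group is exchanged; the number therefore responds to that group alone, and not only to replacement of the whole pendant group. Read with a 6.3-fold higher number from compound 1 to compound 3 (0.80 log units; beyond the scatter), it gives two one-place pairs in which the compound carrying 4-fluorophenyl has the higher number, with neither pair going against this, although the partner groups differ (cyclohexyl in one pair, 4-(tert-butyl)phenyl in the other) and so do the side chains (2-hydroxy-3-methoxyphenyl in one pair, furan-2-yl in the other). Nothing in hand gives a reason for the size or direction of this step.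

The compounds shown leave open whether the step from fluoro to tert-butyl holds when furan-2-yl is replaced by 2-hydroxy-3-methoxyphenyl on the side chain. They also leave open how the number responds at the same place to a group of another kind, such as a carboxylic acid, a primary amine or a methoxy group.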